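The source may report more compounds than this note shows. Statements on the series, on what has been measured and on what is new or still open speak of the compounds shown alone.

Compound 1 `O=C(/C=C/c1ccncc1-c1ccc2[nH]ccc2c1)N1CCOCC1`: "not determined" (no result reported)
Compound 2 `CNC(=O)/C=C/c1ccncc1-c1ccc2cc[nH]c2c1`: 10400 nM
Compound 3 `Cn1ncc2cc(-c3cnccc3/C=C/C(=O)N3CCOCC3)ccc21`: "not determined" (no result reported)

These results come from a functional assay on HCT-116 cells (Homo sapiens) for inhibition, read by MTT assay, with a stated time of 72 h; on this read-out lower numbers stand for stronger inhibition of growth and higher numbers for weaker inhibition of growth. Within the data shown here, compound 2 holds the only number, so it cannot yet be ranked against anything, and compounds 1 and 3 have no reported result. The unmeasured compound 4 `O=C(/C=C/c1ccncc1-c1ccc2cc[nH]c2c1)N1CCOCC1` keeps the core of compound 2 and differs at one place: morpholin-4-yl in place of methylamino on a carbonyl carbon. Among the measured compounds shown here, no measured pair shows what such a swap does in this assay, so no step beyond the usual scatter is expected, and any direction is tentative. The expected step is a 1.5-fold lower number from compound 2 to compound 4 (0.17 log units; within the scatter). For compound 4 the estimate is 7000 nM, with an expected range from 1800 nM to 28000 nM.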

Compound 4, concentration for 50% growth inhibition: > 30000 nM
Compound 4 gave a limit, no number (the forecaster's own chance of this, stated with the estimate: 20%); middle value at least 4.2-fold (0.63 log units) away from the limit.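

In this assay, swapping methylamino for morpholin-4-yl on the carbonyl carbon gives an at least 2.8-fold higher number from compound 2 to compound 4 (0.46 log units; beyond the scatter), so growth inhibition weakens and this position is shown for the first time to respond to a change. Compound 4 gives only a limit, not a number: the limit of > 30000 nM in this assay, at which 1 of the 4 values shown sits. On these data alone, the true size of the step therefore remains unknown.

The swap removes a hydrogen-bond donor and adds a ring at once, so the compounds shown cannot separate these two changes. A dimethylamino group on the same carbonyl carbon, which has no ring and no amide hydrogen, would help to tell them apart.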